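This account rests on a few compounds, and the source may have more. Where it says the series, first, only, none or still open, it means among the compounds named here.

Working notes on the amine series in a functional assay on A549 cells (Homo sapiens) for cytotoxicity, read by MTT assay, with a stated time of 72 h; a lower number here means a stronger inhibitor, a higher number a weaker inhibitor.

Compound 1 `CCN(CC)Cc1ccc(-c2ccnc3ccc(-c4cnc(OC)c(NS(=O)(=O)c5ccc(F)cc5F)c4)cc23)cc1` gives 22 nM in this assay. Compound 2 `CCN(Cc1ccc(-c2ccnc3ccc(-c4cnc(OC)c(NS(=O)(=O)c5ccc(F)cc5F)c4)cc23)cc1)C1CCCCC1` gives 20.2 nM in this assay, and the step of a 1.1-fold lower number from compound 1 to compound 2 (0.04 log units; within the scatter) is within the scatter. Compound 3 `CNCCN(C)Cc1ccc(-c2ccnc3ccc(-c4cnc(OC)c(NS(=O)(=O)c5ccc(F)cc5F)c4)cc23)cc1` gives 13 nM in this assay. Compound 3 stands at the low end of the three numbers, with compound 2 as its nearest neighbour and compound 1 as its furthest, but both steps, a 1.7-fold lower number from compound 1 to compound 3 (0.23 log units; within the scatter) and a 1.6-fold lower number from compound 2 to compound 3 (0.19 log units; within the scatter), sit within the scatter, so the three compounds are not separated in this assay.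

Compound 4 `COc1ncc(-c2ccc3nccc(-c4ccc(CN5CCN(C)CC5)cc4)c3c2)cc1NS(=O)(=O)c1ccc(F)cc1F` is the next member. The change from compound 3 is 4-methylpiperazin-1-yl in place of methyl(2-(methylamino)ethyl)amino on a saturated chain carbon bound to an aromatic carbon. All three measured steps concern replacement of the amine on the saturated chain carbon bound to an aromatic carbon, and none of them moves the number beyond the scatter, whether the amine is acyclic with a donor or acyclic without one, small or bulky. On that basis the step of a 1.2-fold higher number from compound 3 to compound 4 (0.09 log units; within the scatter) is expected to stay within the scatter as well, with no direction favoured. Compound 4 is therefore estimated at 16 nM in this assay, with a range from 7 nM to 36 nM.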

Compound 4, half-maximal inhibitory concentration: 13.3 nM
The estimate for compound 4 lay 1.2-fold (0.08 log units) above the measured number, within the range that was stated.
By their numbers in this assay, from the lowest: compounds 3, 4, 2 and 1 (each within the scatter of the next).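

Among the compounds shown here, compound 4 is the first member in which the amine nitrogen on the saturated chain carbon bound to an aromatic carbon sits inside a ring, and in this assay closing that ring in the form of 4-methylpiperazin-1-yl gives a 1.0-fold higher number from compound 3 to compound 4 (0.01 log units; within the scatter), even though the entering group carries 0 hydrogen-bond donors where methyl(2-(methylamino)ethyl)amino carries 1. The comparisons with the other two acyclic amines, a 1.5-fold lower number from compound 2 to compound 4 (0.18 log units; within the scatter) and a 1.7-fold lower number from compound 1 to compound 4 (0.22 log units; within the scatter), also stay within the scatter, so this position now tolerates a cyclic amine as well as acyclic ones, and the four compounds are not separated in this assay. No supporting data are available to account for this flat response at the position.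

Still open, as far as these compounds go, is whether the number in this assay would move with morpholin-4-yl, a carboxylic acid or a hydroxyl on that saturated chain carbon. Also open, from the compounds shown here alone, is whether the same flat response would hold with a longer chain carrying the amine in place of the single saturated carbon.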